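Swapping tert-butyl for pyrimidin-2-yl on the amide nitrogen

The compounds below may be only part of what the source reports. "The series", "measured", "known", "first", "only" and "open" are said of these compounds alone.

Measured compounds:
Compound 1, `Cc1ccc(OCC(=O)N(Cc2cccs2)C(C)(C)C)cc1`, with 11000 nM
Compound 2, `COc1ccc2oc(C(=O)N(Cc3cccs3)c3ccn[nH]3)cc2c1`, with 1.1 nM

Both were tested in an assay on HEK293 cells for agonist activity at transient receptor potential cation channel subfamily M member 8 (Homo sapiens), read by fluorescence and calcium flux, with a stated time of 15 min; on this read-out higher numbers stand for an effect only at larger amounts of compound and lower numbers for an effect already at smaller amounts. Compound 1 gives 11000 nM, the highest of the two numbers, while compound 2 gives 1.1 nM, a gap that lies far beyond the scatter. Among the measured compounds shown here, the two differ in several places at once, so no single step between them can be read off.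

Compound 3, `Cc1ccc(OCC(=O)N(Cc2cccs2)c2ncccn2)cc1`, has not been measured. It differs from compound 1 in one place:

pyrimidin-2-yl in place of tert-butyl on an amide-type nitrogen

Compound 2 also carries a nitrogen-containing ring on its amide-type nitrogen and sits at the low end, though its other parts differ as well, so this is only a loose hint. A drop in the number is expected from compound 1 to compound 3, estimated at a 37-fold lower number from compound 1 to compound 3 (1.56 log units; beyond the scatter). Compound 3 is therefore expected to give 300 nM, with a range from 30 nM to 3000 nM.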

Compound 3, half-maximal effective concentration: 3700 nM
Compound 3: the middle estimate sits 12-fold (1.09 log units) below what was measured, outside the stated range (above it).
By their numbers in this assay, from the lowest: compound 2; then compound 3; then compound 1.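

In this assay the amide-type nitrogen of compound 1 accepts an aromatic ring in place of a branched carbon group, and pyrimidin-2-yl for tert-butyl brings only a modest gain (a 3.0-fold lower number from compound 1 to compound 3 (0.47 log units; beyond the scatter)). This single change therefore accounts for little of the wide gap that separates compound 1 from compound 2, although steps from compound 2 to either of the others cannot be read, as it differs from both in several places. Nothing measured here explains why the step has this size.

A plain phenyl group on the same nitrogen would help show whether the ring itself or its two nitrogen atoms matter for the step. From the compounds shown here alone, the effect of changing the other parts of compound 3 while keeping pyrimidin-2-yl in place also remains open.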